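Silyl to acetyl exchange on the primary oxygen

The compounds below may be only part of what the source reports. "The series", "measured", "known", "first", "only" and "open" are said of these compounds alone.

Measured compounds:
compound 1 `C=C1CC[C@@H]2[C@](C)(COC(C)=O)[C@H](O)CC[C@@]2(C)[C@@H]1C/C=C1/C(=O)OC[C@H]1OC(C)=O` 16.3 uM
compound 2 `C=C1CC[C@@H]2[C@](C)(CO[Si](C(C)C)(C(C)C)C(C)C)[C@H](OC(C)=O)CC[C@@]2(C)[C@@H]1C/C=C1/C(=O)OC[C@H]1OC(C)=O` 7.56 uM
compound 3 `C=C1CC[C@@H]2[C@](C)(CO[Si](C)(C)C(C)(C)C)[C@H](OC(C)=O)CC[C@@]2(C)[C@@H]1C/C=C1/C(=O)OC[C@H]1OC(C)=O` 1.22 uM

In a functional assay on ASK cells (Rattus norvegicus) for cytotoxicity, read by sulforhodamine B assay (a higher number here means that more compound is needed for the effect, a lower number that less compound is needed), compound 3 stands at the lowest number of the three, and both gaps to the others are beyond the scatter: compound 2 sits above it by a 6.2-fold lower number from compound 2 to compound 3 (0.79 log units; beyond the scatter) read in reverse, compound 1 further still.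

Compound 4 `C=C1CC[C@@H]2[C@](C)(COC(C)=O)[C@H](OC(C)=O)CC[C@@]2(C)[C@@H]1C/C=C1/C(=O)OC[C@H]1OC(C)=O` is not yet measured. Relative to compound 3 the change is a group of 3 heavy atoms (2 carbon, 1 oxygen; no ring) in place of a group of 7 heavy atoms (6 carbon, 1 silicon; no ring), on an oxygen on a saturated carbon. Among the measured compounds shown here, the only measured step at this oxygen is a 6.2-fold lower number from compound 2 to compound 3 (0.79 log units; beyond the scatter), a modest move between two groups of related kind; it does not reach the acetyl. Compound 1 carries the acetyl at this oxygen and, differing from compound 4 only at the secondary oxygen, gives the highest number here; no step between compound 1 and compound 4 is shown, so only the two values speak.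

The expectation for compound 4 is therefore a higher number than compound 3 in this assay, roughly a 6.6-fold higher number from compound 3 to compound 4 (0.82 log units; beyond the scatter), landing nearer the range of compound 1 and compound 2. Compound 4 is estimated at 8 uM, with a range of 2.5 uM to 25 uM.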

Compound 4, concentration for half-maximal effect: 11.4 uM
The estimate for compound 4 lay 1.4-fold (0.15 log units) below the measured number, within the range that was stated.
By their numbers in this assay, from the lowest: compound 3; then compounds 2, 4 and 1 (each within the scatter of the next, the first and the last beyond it).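

Among the compounds shown here, the acetyl at this oxygen gives the first comparison with a silicon-bearing group that is not another such group, a 9.3-fold higher number from compound 3 to compound 4 (0.97 log units; beyond the scatter) in this assay, so the low number of compound 3 is tied to its own group at this oxygen. Silicon alone does not account for it, as the other silicon-bearing group stays within the scatter of the acetyl, a 1.5-fold higher number from compound 2 to compound 4 (0.18 log units; within the scatter). Acetyl in place of hydrogen on the other oxygen also stays within the scatter, a 1.4-fold lower number from compound 1 to compound 4 (0.16 log units; within the scatter), and no measurement at hand explains any of these steps.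

Going by these compounds, whether a benzoyl ester, a longer acyl chain or a methyl ether at this oxygen would come close to compound 3 remains open. So does whether the number of compound 3 depends on the acetyl kept on the other oxygen.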